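A few compounds are considered here, and "the series" means these few. Any claim that something is new, unique, unknown or untested is made for them only; others in the source may bear on it.

Measured so far in a functional assay on HepG2 cells (Homo sapiens) for cytotoxicity, read by MTT assay, with a stated time of 48 h; a lower number here means a stronger inhibitor, a higher number a weaker inhibitor:
- compound 1, `COc1cc(/C=C/C(=O)/C=C/c2nc3ccccc3n2C)ccc1O`: 2900 nM
- compound 2, `COc1cc(/C=C/C(=O)/C=C/c2nc3cc(C)ccc3n2C)ccc1O`: 4200 nM
- compound 3, `COc1cc(/C=C/C(=O)/C=C/c2nc3cc(Cl)ccc3n2C)ccc1O`: 4000 nM

Compound 3 sits second highest of the three numbers in this assay; its nearest neighbour is compound 2, with a 1.1-fold lower number from compound 2 to compound 3 (0.02 log units; within the scatter), and the widest gap is to compound 1, with a 1.4-fold higher number from compound 1 to compound 3 (0.14 log units; within the scatter). All three compounds therefore lie within the scatter of one another, and no ordering among them can be claimed.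

Compound 4, `COc1cc(/C=C/C(=O)/C=C/c2nc3cc(O)ccc3n2C)ccc1O`, is the next member. Its change from compound 3 is hydroxy in place of chloro on an aromatic carbon. For the measured compounds named here, the steps that bear on this position are those into compound 3 itself: a 1.4-fold higher number from compound 1 to compound 3 (0.14 log units; within the scatter) and a 1.1-fold lower number from compound 2 to compound 3 (0.02 log units; within the scatter), together with a 1.4-fold higher number from compound 1 to compound 2 (0.16 log units; within the scatter) at the same carbon. Each of these is within the scatter, so three different groups at this carbon have left the number essentially unchanged. Going by the values given here, no measured compound carries a hydroxy there, so the hydroxy case itself is untested; the expectation nonetheless is that compound 4 shows no step beyond the scatter in this assay.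

Compound 4 is expected to give 3600 nM, with a range from 1500 nM to 9000 nM. This estimate implies a 1.1-fold lower number from compound 3 to compound 4 (0.05 log units; within the scatter), expected to remain within the scatter.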

Compound 4, half-maximal inhibitory concentration: 3600 nM
The estimate for compound 4 equals the measured number at the digits printed; the measured number falls inside the stated range.
By their numbers in this assay, from the lowest: compounds 1, 4, 3 and 2 (each within the scatter of the next).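

In this assay, hydroxy at this carbon introduces a hydrogen-bond donor and a hydrogen-bond acceptor where chloro has neither, yet the number stays within the scatter of all three earlier groups (a 1.1-fold lower number from compound 3 to compound 4 (0.05 log units; within the scatter); a 1.2-fold lower number from compound 2 to compound 4 (0.07 log units; within the scatter); a 1.2-fold higher number from compound 1 to compound 4 (0.09 log units; within the scatter)). Across compounds 1 to 4, this carbon has therefore taken hydrogen, methyl, chloro and hydroxy with no step beyond the scatter, and no compound here goes against that flat picture. No available evidence accounts for this lack of response.

Still open, on these data alone, is whether an amine, a carboxylic acid or a longer chain at this carbon would also stay within the scatter. The four compounds also leave open how changes elsewhere on the shared core would behave, since they vary at this one carbon only.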